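Furan for Phenyl on a Carbamate Inhibitor of Monoglyceride Lipase

The compounds below may be only part of what the source reports. "The series", "measured", "known", "first", "only" and "open" are said of these compounds alone.

Measured compounds:
compound 1, `O=C(Nc1cccc(-c2ccccc2)c1)OCc1ccccc1`, 16500 nM
compound 2, `O=C(Nc1cccc(-c2ccc(C(F)(F)F)cc2)c1)OCC1CCCCC1`, 17400 nM
compound 3, `O=C(Nc1cccc(-c2ccc(C(F)(F)F)cc2)c1)OCc1ccccc1`, 9410 nM

In an assay on B16-F10 cells for inhibition of Monoglyceride lipase (Mus musculus), read by fluorescence, with stated times of 60 min, 2.5 min and 2 h (on this read-out higher numbers stand for weaker inhibition and lower numbers for stronger inhibition), compound 3 gives the lowest of the three numbers, yet both neighbours sit within the scatter: a 1.8-fold lower number from compound 1 to compound 3 (0.24 log units; within the scatter) and a 1.8-fold lower number from compound 2 to compound 3 (0.27 log units; within the scatter). Neither change, the trifluoromethyl nor the phenyl in place of cyclohexyl, moved the read-out beyond what repeated measurement would show.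

Compound 4, `O=C(Nc1cccc(-c2ccc(C(F)(F)F)cc2)c1)OCc1ccco1`, is the next step: furan-2-yl in place of phenyl on a saturated chain carbon bound to an oxygen next to a carbonyl group. Going by the values given here, the one measured step at the same place, a 1.8-fold lower number from compound 2 to compound 3 (0.27 log units; within the scatter), was within the scatter, so there is no sign so far that changes on that chain carbon shift the number much. Among the compounds with values here, no measured step swaps one aromatic ring for another here, so the expectation rests on that single step alone.

Compound 4 is therefore expected to stay close to compound 3 in this assay, with a step of a 1.0-fold higher number from compound 3 to compound 4 (0.00 log units; within the scatter) meaning no change beyond the scatter. The estimate for compound 4 is 9500 nM, with a range from 4000 nM to 25000 nM.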

Compound 4, half-maximal inhibitory concentration: 13200 nM
For compound 4 the middle estimate is 1.4-fold (0.14 log units) below the measured one, within the range that was stated.
By their numbers in this assay, from the lowest: compounds 3, 4, 1 and 2 (each within the scatter of the next).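

In this assay, furan-2-yl in place of phenyl gives a 1.4-fold higher number from compound 3 to compound 4 (0.15 log units; within the scatter), so at this saturated chain carbon bound to an oxygen next to a carbonyl group, a five-membered aromatic ring with one hetero atom reads the same as a six-membered carbon ring within the scatter. Furan-2-yl in place of cyclohexyl gives a 1.3-fold lower number from compound 2 to compound 4 (0.12 log units; within the scatter), which means that all three rings now seen at this place, aromatic or saturated, stand within the scatter of one another. Nothing available explains why these rings read alike.

On these data alone, what remains open is whether any group at this place can move the number beyond the scatter. A longer chain in place of benzyl, or a ring carrying an amine or a carboxylic acid, would test this.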